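A Hydroxy Analogue Tested for Toxicity Toward Cancer Cells

A few compounds are considered here, and "the series" means these few. Any claim that something is new, unique, unknown or untested is made for them only; others in the source may bear on it.

Compound 1, `O=C(Nc1cccc(-n2cc(-c3ccncc3)c(-c3ccc(Cl)c(O)c3)n2)c1)Nc1cccc(C(F)(F)F)c1`: in a functional assay on MCF7 cells (Homo sapiens) for inhibition, read by sulforhodamine B assay, with a stated time of 48 h (on this read-out higher numbers stand for lower toxicity in this test and lower numbers for higher toxicity in this test), compound 1 gives > 32500 nM, which is a limit of the test, not a number.
Compound 2, `COc1cc(-c2nn(-c3cccc(NC(=O)c4cccc(C(F)(F)F)c4)c3)cc2-c2ccncc2)ccc1Cl`: in this assay compound 2 gives > 50000 nM, again a limit.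
Compound 3, `COc1cc(-c2nn(-c3cccc(NC(=O)Nc4ccc(Cl)c(Cl)c4)c3)cc2-c2ccncc2)ccc1Cl`: in this assay compound 3 gives > 50000 nM, also a limit.

Compound 3 therefore stands at the edge of what the test can report, at the limit of > 50000 nM in this assay, at which 2 of the 3 values shown sit. Going by the values given here, the only step between measured compounds is a step that the two limits leave unreadable from compound 2 to compound 3, so it tells nothing about size or direction.

Compound 4, `O=C(Nc1cccc(-n2cc(-c3ccncc3)c(-c3ccc(Cl)c(O)c3)n2)c1)Nc1ccc(Cl)c(Cl)c1`, differs from compound 3 by hydrogen in place of methyl on an oxygen on an aromatic ring. Among the compounds with values here, no measured step covers this change. Compound 1, which carries the same hydroxy group with a different urea partner, sits at the limit of > 32500 nM in this assay, at which 1 of the 3 values shown sits, so every compound here has stayed at a limit. With nothing pointing to a readable step, no change beyond the scatter is expected in this assay, and compound 4 is expected to give a value near 50000 nM, estimated between 15000 nM and 160000 nM. The expected step is a number no higher from compound 3 to compound 4 (the limit leaves the size open), most likely returning only a limit once more.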

Compound 4, concentration lethal to 50% of the cells: > 32500 nM
Compound 4 gave a limit, no number (the forecaster's own chance of this, stated with the estimate: 70%); the middle value does not contradict the limit.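

Compound 4 also ends at a limit of the test, so its steps from compound 3 and from compound 1 cannot be read in size or direction. The compounds shown leave open whether swapping methoxy for hydroxy, or changing the urea partner, alters the result in this assay at all.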